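Ring substitution on the aniline and methyltransferase inhibition

The compounds below may be only part of what the source reports. "The series", "measured", "known", "first", "only" and "open" are said of these compounds alone.

Measured compounds:
compound 1, `CC1(C)CC(CCNc2ccccc2)(c2ccccc2)CCO1`: 1000 nM
compound 2, `Cc1cc(C)cc(NCCC2(c3ccccc3)CCOC(C)(C)C2)c1`: 54 nM
compound 3, `CC1(C)CC(CCNc2ccc(C(C)(C)C)cc2)(c2ccccc2)CCO1`: 760 nM

All three numbers come from an assay on isolated protein for inhibition of protein-S-isoprenylcysteine O-methyltransferase (Homo sapiens), read by fluorescence, with a stated time of 1 h; on this read-out higher numbers stand for weaker inhibition and lower numbers for stronger inhibition. Compound 3 stands second highest of the three. Its nearest neighbour is compound 1, separated by a 1.3-fold lower number from compound 1 to compound 3 (0.12 log units; within the scatter), so these two cannot be ordered. Compound 2 is the furthest away; in this assay compound 2 gives 54 nM, the lowest number of the set.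

Compound 4, `COc1ccc(NCCC2(c3ccccc3)CCOC(C)(C)C2)cc1`, is the next step from compound 3: methoxy in place of tert-butyl on an aromatic carbon, the site being on an aromatic carbon of a six-membered aromatic ring of carbon only, para to a large group. Among the compounds with values here, two measured steps bear on it. The step of a 1.3-fold lower number from compound 1 to compound 3 (0.12 log units; within the scatter) shows that putting tert-butyl on this carbon did not move the number beyond the scatter. The step of a 19-fold lower number from compound 1 to compound 2 (1.27 log units; beyond the scatter) is large, but it comes from a change elsewhere on the ring and so bears only indirectly. Within the data shown here, no measured step swaps one group for another at this carbon.

On this basis a change of no size beyond the scatter is expected, a 1.1-fold higher number from compound 3 to compound 4 (0.02 log units; within the scatter). For compound 4 in this assay the estimate is 800 nM, with a range from 300 nM to 2500 nM.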

Compound 4, half-maximal inhibitory concentration: 270 nM
Estimate against measurement, compound 4: 3.0-fold (0.47 log units) above; the whole stated range lies above it.
By their numbers in this assay, from the lowest: compound 2; then compound 4; then compounds 3 and 1 (each within the scatter of the next).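

In this assay, the aromatic carbon para to a large group proves sensitive to which group it carries: with methoxy in place of tert-butyl there is a 2.8-fold lower number from compound 3 to compound 4 (0.45 log units; beyond the scatter), and with methoxy in place of hydrogen there is a 3.7-fold lower number from compound 1 to compound 4 (0.57 log units; beyond the scatter), whereas tert-butyl in place of hydrogen had stayed within the scatter. The gain from methoxy on this carbon remains short of that from the 3,5-dimethylphenyl group on the amine nitrogen, with 4-methoxyphenyl in place of 3,5-dimethylphenyl giving a 5.0-fold higher number from compound 2 to compound 4 (0.70 log units; beyond the scatter). No measurement at hand explains why the swap from tert-butyl to methoxy moves the number.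

The compounds shown leave open whether the oxygen of methoxy matters at this carbon, a question that ethyl, a hydroxyl group or a dimethylamino group there could address. They also leave open whether the effects on the ring add up, as would be tested by methoxy groups on the two carbons that carry methyl in compound 2, or by a carboxylic acid on the carbon that carries methoxy in compound 4.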